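This account rests on a few compounds, and the source may have more. Where it says the series, first, only, none or still open, it means among the compounds named here.

Of the compounds shown here, three sharing one core have been tested in a functional assay on K562 cells (Homo sapiens) for cytotoxicity; a higher number here means a weaker inhibitor, a lower number a stronger inhibitor. Compound 1 `CCC(CO)Nc1nc(NCc2ccccc2)c2nc(Cl)n(C(C)C)c2n1`, which carries chloro on an aromatic carbon, gives 91000 nM. Compound 2 `CCC(CO)Nc1nc(NCc2ccccc2)c2nc(N)n(C(C)C)c2n1`, with amino at that carbon, gives 80000 nM. Compound 3 `CCC(CO)Nc1nc(NCc2ccccc2)c2nc(O)n(C(C)C)c2n1`, with hydroxy there, gives 74000 nM. On these numbers compound 3 stands level with the other two, since all three values lie within the usual scatter of one another.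

The next compound, compound 4 `CCCOc1nc2c(NCc3ccccc3)nc(NC(CC)CO)nc2n1C(C)C`, keeps the core and alters that hydroxy group: propyl in place of hydrogen on an oxygen on an aromatic ring. This places propyl in place of hydrogen on an oxygen on an aromatic ring, turning hydroxy into propoxy.

The measured steps that bear on this change are the swaps at the same carbon. They are a 1.1-fold lower number from compound 1 to compound 2 (0.06 log units; within the scatter), then a 1.2-fold lower number from compound 1 to compound 3 (0.09 log units; within the scatter), and finally a 1.1-fold lower number from compound 2 to compound 3 (0.03 log units; within the scatter). None of them moved the number beyond the scatter. However, no measured compound carries a propyl chain, so they are only a loose guide, and the expected range must stay wide. The expected change is a 1.1-fold lower number from compound 3 to compound 4 (0.02 log units; within the scatter), which means no step beyond the scatter is anticipated in this assay. For compound 4 the estimated value is 70000 nM, with an expected range from 30000 nM to 130000 nM.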

Compound 4, half-maximal inhibitory concentration: 20000 nM
Beside the measured number, compound 4's estimate is 3.5-fold (0.54 log units) above it, outside the stated range (below it).
By their numbers in this assay, from the lowest: compound 4; then compounds 3, 2 and 1 (each within the scatter of the next).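

In this assay, going by these compounds alone, the change from hydroxy to propoxy gives a 3.7-fold lower number from compound 3 to compound 4 (0.57 log units; beyond the scatter) and is the first change at this position to move the number beyond the scatter, whereas swaps among chloro, amino and hydroxy had left the values level. The picture is the same when propoxy is compared with the other two groups, with a 4.0-fold lower number from compound 2 to compound 4 (0.60 log units; beyond the scatter) for the replacement of amino and a 4.6-fold lower number from compound 1 to compound 4 (0.66 log units; beyond the scatter) for the replacement of chloro, so this position can affect the result, though each of these steps is only modest. Nothing in the data shown explains why adding a propyl group to the oxygen lowers the number.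

From the compounds shown here alone, with a single alkoxy group in the set, it remains open whether the shift depends on the length of the chain, which shorter methoxy and ethoxy groups or a longer butoxy group could test. It is also unclear whether the oxygen link matters or the propyl chain alone is enough, a question that a propylamino group at the same carbon could help to answer.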